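The source may report more compounds than this note shows. Statements on the series, on what has been measured and on what is new or still open speak of the compounds shown alone.

In a toxicity assay on Huh-7.5 cells (Homo sapiens) for inhibition, read by MTT assay, with a stated time of 96 h (a higher number here means that more compound is tolerated, a lower number that less compound is tolerated), compound 1 `COc1ccc(NC(=O)c2ccc(OCCCCl)c([N+](=O)[O-])c2)cc1` gives 39700 nM, which offers one exact point of reference. Compound 2 `O=C(Nc1ccc(CN2CC(C(=O)O)C2)c(C(F)(F)F)c1)c1ccc(OCCCCl)c([N+](=O)[O-])c1` gives > 200000 nM in this assay, and this is a limit of the assay, not a number. Compound 2 therefore provides no exact starting figure.

Compound 3 `CN(C)C1CCN(Cc2ccc(NC(=O)c3ccc(OCCCCl)c([N+](=O)[O-])c3)cc2C(F)(F)F)CC1` differs from compound 2 in one place: 4-(dimethylamino)piperidin-1-yl in place of 3-carboxyazetidin-1-yl on a saturated chain carbon bound to an aromatic carbon. The count of what changes is 4-(dimethylamino)piperidin-1-yl in place of 3-carboxyazetidin-1-yl on a saturated chain carbon bound to an aromatic carbon.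

Among the compounds with values here, no pair of measured compounds shows this swap, so any forecast rests on thin evidence. Within the data shown here, compound 1, which carries neither of these groups, gives 39700 nM, and this is the only exact value available as a guide. Once the 3-carboxyazetidin-1-yl group is gone, compound 3 is expected to land near that value, well away from the limit reached by compound 2. The expected step is large and points toward less compound being tolerated: an at least 10-fold lower number from compound 2 to compound 3 (1.00 log units; beyond the scatter). For compound 3 the estimate is 20000 nM, with an expected range from 6000 nM to 70000 nM.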

Compound 3, half-maximal cytotoxic concentration: 5500 nM
The estimate for compound 3 lay 3.6-fold (0.56 log units) above the measured number; the whole stated range lies above it.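

In this assay, within the data shown here, this is the first direct view of what the group on this saturated chain carbon does when the rest of the molecule stays the same. Placing 4-(dimethylamino)piperidin-1-yl there instead of 3-carboxyazetidin-1-yl gives an at least 36-fold lower number from compound 2 to compound 3 (1.56 log units; beyond the scatter), so the choice of group at this position has a large effect on how much compound the cells tolerate. The true size of the step stays unknown because compound 2 gives a limit and not a number, so the step can only be stated as a minimum: the limit of > 200000 nM in this assay, at which 1 of the 3 values shown sits.

The swap replaces a four-membered ring bearing a carboxylic acid with a six-membered ring bearing a dimethylamino group, so several features change together and the compounds shown cannot say which of them accounts for the step. From the compounds shown here alone, a plain piperidin-1-yl group, or an azetidin-1-yl group without the carboxylic acid, would separate ring size from the group the ring carries, and whether the same step would appear on another core remains open.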